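Swapping the amine substituent: from compound 3 to compound 4

This account rests on a few compounds, and the source may have more. Where it says the series, first, only, none or still open, it means among the compounds named here.

Of the compounds shown here, three sharing one core have been tested in a functional assay on Huh-7 cells (Homo sapiens) for antiproliferative activity, read by sulforhodamine B assay, with a stated time of 72 h; on this read-out lower numbers stand for stronger inhibition and higher numbers for weaker inhibition. Compound 1 `FC(F)(F)c1ccc(CN2CCN(Cc3cc(-c4ccc(OCc5ccccc5)cc4)on3)CC2)cc1` gives 1700 nM. Within the data shown here, compound 2 `Cc1ccccc1COc1ccc(-c2cc(CN3CCN(Cc4ccc(C(F)(F)F)cc4)CC3)no2)cc1` gives 1200 nM, and the step of a 1.4-fold lower number from compound 1 to compound 2 (0.15 log units; within the scatter) is the only single-point comparison among the measured compounds. Compound 3 `N#Cc1cccc(COc2ccc(-c3cc(CN4CCN(c5ccc(C(F)(F)F)cc5)CC4)no3)cc2)c1` gives 2200 nM, the highest of the three numbers, though its distance to compound 1 and to compound 2 stays within the scatter, so the three cannot be ranked.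

Compound 4 `N#Cc1cccc(COc2ccc(-c3cc(CN4CCN(Cc5ccccc5F)CC4)no3)cc2)c1` differs from compound 3 in one place: 2-fluorobenzyl in place of 4-(trifluoromethyl)phenyl on an amine nitrogen in a ring. Among the measured compounds shown here, no measured step touches this position. The step from compound 1 to compound 2 lies elsewhere in the molecule and was within the scatter, so it gives no guidance on direction. Compounds 1 and 2 do carry a different group on the same amine nitrogen as compound 3, and their numbers sit within the scatter of compound 3, which suggests this nitrogen tolerates change without a large shift in this assay.

Compound 4 is therefore expected to give 1800 nM, within a range from 800 nM to 4000 nM. The expected step of a 1.2-fold lower number from compound 3 to compound 4 (0.09 log units; within the scatter) is estimated to stay within the scatter.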

Compound 4, half-maximal inhibitory concentration: 2400 nM
Compound 4: the middle estimate sits 1.3-fold (0.12 log units) below what was measured; measured number inside the range.
By their numbers in this assay, from the lowest: compounds 2, 1, 3 and 4 (each within the scatter of the next).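

In this assay, among these compounds, exchanging 4-(trifluoromethyl)phenyl for 2-fluorobenzyl on the amine nitrogen gives a 1.1-fold higher number from compound 3 to compound 4 (0.04 log units; within the scatter), and this is the first step measured at this position. It shows that these two groups cannot be told apart in this read-out, even though the exchange alters the substituent in more than one way: the fluorine count differs, and the trifluoromethyl gives way to a single fluorine on a benzyl group. The two groups are alike in other ways, each having one six-membered aromatic ring of carbon only, no hydrogen-bond donors or acceptors and no net charge, and nothing measured here offers a reason for the result.

As far as these compounds go, since compound 3 and compound 4 both carry an aromatic ring at this position, it remains open whether the ring itself matters, which a plain methyl group, an acetyl group or a short chain ending in a carboxylic acid on the same nitrogen could test. From the compounds shown here alone, it is also open whether a primary amine on that chain would give a number beyond the usual scatter.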